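The source may report more compounds than this note shows. Statements on the series, on what has been measured and on what is new or still open speak of the compounds shown alone.

Compound 3, whose structure is `COc1cc(C(=O)N2CC[C@@H](O)[C@H](C)C2)cc2nc(NCc3cccc(Cl)c3)oc12`, gives 10 nM in an assay on isolated protein for inhibition of thyroid hormone receptor beta (Homo sapiens), read by fluorescence, with a stated time of 30 min; on this read-out higher numbers stand for weaker inhibition and lower numbers for stronger inhibition. That is the lowest of the three numbers shown, but compound 1, `CCCN(CC1CCOC1)C(=O)c1cc(OC)c2oc(NCc3cccc(Cl)c3)nc2c1`, gives 12 nM in this assay, and a 1.2-fold lower number from compound 1 to compound 3 (0.08 log units; within the scatter), so the two cannot be ordered. Compound 2, `COc1cc(C(=O)N2CCCC2)cc2nc(NCc3cccc(Cl)c3)oc12`, gives 180 nM in this assay, and an 18-fold lower number from compound 2 to compound 3 (1.26 log units; beyond the scatter), while a 15-fold higher number from compound 1 to compound 2 (1.18 log units; beyond the scatter).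

Compound 4 is `CCC1CC(O)C(C)CN1C(=O)c1cc(OC)c2oc(NCc3cccc(Cl)c3)nc2c1`, and it differs from compound 3 in one place: 2-ethyl-4-hydroxy-5-methylpiperidin-1-yl in place of 4-hydroxy-3-methylpiperidin-1-yl on a carbonyl carbon. The measured steps that bear on this are the exchanges of the group on the same carbonyl carbon. Both large steps, from compound 2 to compound 3 and from compound 1 to compound 2, involve pyrrolidin-1-yl; the step from compound 1 to compound 3, which exchanges one larger group for another, is within the scatter. Compound 4 keeps the hydroxy and methyl of compound 3 and only gains an ethyl on the same ring. Going by the values given here, no measured step shows such an addition, so the expectation is a step of modest size at most, and compound 4 is expected to show a 1.5-fold higher number from compound 3 to compound 4 (0.18 log units; within the scatter). Compound 4 is therefore estimated at 15 nM in this assay, within a range from 5 nM to 45 nM.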

Compound 4, half-maximal inhibitory concentration: 13 nM
The estimate for compound 4 lay 1.2-fold (0.06 log units) above the measured number; low and high end bracket the measured number.
By their numbers in this assay, from the lowest: compounds 3, 1 and 4 (each within the scatter of the next); then compound 2.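

Going from 4-hydroxy-3-methylpiperidin-1-yl to 2-ethyl-4-hydroxy-5-methylpiperidin-1-yl on the carbonyl carbon enlarges the group from 8 to 10 heavy atoms and gives a 1.3-fold higher number from compound 3 to compound 4 (0.11 log units; within the scatter) in this assay, so this position takes the added ethyl with no change that can be told from the scatter. The new group also gives a 14-fold lower number from compound 2 to compound 4 (1.14 log units; beyond the scatter) and a 1.1-fold higher number from compound 1 to compound 4 (0.03 log units; within the scatter), which leaves three differently built groups at one level and pyrrolidin-1-yl alone apart from them among the four compounds. The data shown offer no account of why the added ethyl leaves the number within the scatter or why pyrrolidin-1-yl stands apart.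

As far as these compounds go, compound 4 is drawn without defined stereocentres, whereas the group in compound 3 has 2, so it stays open whether a single stereoisomer of the new group would give a different number. Also open, from the compounds shown here alone, is how far this tolerance extends, for instance whether a longer chain such as butyl in place of the ethyl, or an amine or a carboxylic acid in place of the hydroxy, would keep the number at this level.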